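Swapping Chloro for Nitro on a Second Core

The compounds below may be only part of what the source reports. "The series", "measured", "known", "first", "only" and "open" are said of these compounds alone.

Measured compounds in a functional assay on A549 cells (Homo sapiens) for antiproliferative activity, read by MTT assay, with a stated time of 48 h; on this read-out higher numbers stand for weaker inhibition and lower numbers for stronger inhibition:
compound 1 `COc1ccc(N(C)c2ccnc(Cl)n2)cc1Cl` gives 621 nM
compound 2 `COc1ccc(N(C)c2ccnc(Cl)n2)cc1[N+](=O)[O-]` gives 3780 nM
compound 3 `COc1ccc(N(C)c2cc(C)nc(C)n2)cc1Cl` gives 780 nM

Compound 2 differs from compound 1 by one change, (nitro in place of chloro on an aromatic carbon), and this gave a 6.1-fold higher number from compound 1 to compound 2 (0.78 log units; beyond the scatter). Compound 3 carries a different core; the difference between the two cores is not broken down here. Compound 4 `COc1ccc(N(C)c2cc(C)nc(C)n2)cc1[N+](=O)[O-]` is compound 3 with the same kind of change, (nitro in place of chloro on an aromatic carbon), where the surroundings are described as meta to a large group rather than meta to a group of 9 heavy atoms. Compound 4 is not yet measured. For the measured compounds named here, the step from compound 3 to compound 4 is expected to be a 5.8-fold higher number from compound 3 to compound 4 (0.76 log units; beyond the scatter), resting on the one earlier instance, compound 1 to compound 2, which gave a 6.1-fold higher number from compound 1 to compound 2 (0.78 log units; beyond the scatter), a single example. Compound 4 is therefore estimated at 4500 nM, likely between 1500 nM and 13000 nM.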

Compound 4, half-maximal inhibitory concentration: 3270 nM
Beside the measured number, compound 4's estimate is 1.4-fold (0.14 log units) above it; low and high end bracket the measured number.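

In this assay, nitro in place of chloro on the core of compound 3 gave a 4.2-fold higher number from compound 3 to compound 4 (0.62 log units; beyond the scatter). Set beside the earlier case, the two steps agree: the same change on two cores in this assay, a 6.1-fold higher number (0.78 log units; beyond the scatter) from compound 1 to compound 2 and a 4.2-fold higher number (0.62 log units; beyond the scatter) from compound 3 to compound 4, 1.5-fold (0.16 log units) apart, within the scatter of two such steps. So the change carried over between these two cores with a similar size and the same direction, but a single pair of cores cannot show that it would do so on any other core, and these numbers alone do not explain what lies behind the step.

The compounds shown leave open where other groups in the same place on the aromatic ring, such as an amine or a carboxylic acid, would fall relative to chloro and nitro. They also leave open whether the step holds when the methoxy group gives way to a longer chain.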